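Amidine Benzyl Ether Replacing Pentyl: Expected Cytotoxicity

A few compounds are considered here, and "the series" means these few. Any claim that something is new, unique, unknown or untested is made for them only; others in the source may bear on it.

Measured compounds:
Compound 1 `Cc1ccc(C(F)(F)F)cc1COc1cc(NC(=O)c2cc(C(F)(F)F)cc(C(F)(F)F)c2)ccc1N(C)S(C)(=O)=O` — > 500000 nM
Compound 2 `CCCCCCOc1cc(NC(=O)c2cc(C(F)(F)F)cc(C(F)(F)F)c2)ccc1N(C)S(C)(=O)=O` — > 500000 nM

In an ADME assay on HEK293 cells (Homo sapiens) for cytotoxicity, read by MTT assay, with a stated time of 48 h (on this read-out lower numbers stand for stronger inhibition and higher numbers for weaker inhibition), compound 1 gives > 500000 nM, which is a limit of the assay rather than a number. In this assay compound 2 likewise gives > 500000 nM, again only a limit. Compound 2 therefore stands at the limit of > 500000 nM in this assay, at which 2 of the 2 values shown sit. The step that the two limits leave unreadable from compound 1 to compound 2 stays unreadable between two limits.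

Compound 3 `CN(c1ccc(NC(=O)c2cc(C(F)(F)F)cc(C(F)(F)F)c2)cc1OCc1cccc(C(=N)N)c1)S(C)(=O)=O` differs from compound 2 by a group of 9 heavy atoms (7 carbon, 2 nitrogen; one six-membered aromatic ring of carbon only) in place of a group of 5 heavy atoms (5 carbon; no ring), on a saturated chain carbon bound to an oxygen on an aromatic ring. Among the compounds with values here, no measured step offers a readable size to guide this change. Compound 3 is expected to give 400000 nM, with a range from 100000 nM to 600000 nM. That expectation corresponds to an estimated step of an at least 1.2-fold lower number from compound 2 to compound 3 (0.09 log units; that floor lies within the scatter), most likely another limit.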

Compound 3, half-maximal inhibitory concentration: > 500000 nM
Compound 3 ended at the assay's limit; the forecaster's own chance of this, stated with the estimate: 80%; at least 1.2-fold (0.09 log units) between middle value and limit.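

Compound 1, compound 2 and compound 3 all give only a limit in this assay, so no step among them can be read: the limit of > 500000 nM in this assay, at which 3 of the 3 values shown sit.

Going by these compounds, whether swapping these groups changes cytotoxicity at all remains open.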